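Aryl urea series: chloro in place of isopropyl

The source may report more compounds than this note shows. Statements on the series, on what has been measured and on what is new or still open speak of the compounds shown alone.

Measured so far in a functional assay on SMMC-7721 cells (Homo sapiens) for inhibition, read by MTT assay, with a stated time of 48 h; on this read-out lower numbers stand for stronger inhibition and higher numbers for weaker inhibition:
compound 1 `Cc1ccc(NC(=O)Nc2cccc(-c3cccc4[nH]nc(N)c34)c2)cc1Cl`: 510 nM
compound 2 `CC(C)c1cccc(NC(=O)Nc2cccc(-c3cccc4[nH]nc(N)c34)c2)c1`: 280 nM

Compound 2 holds the lower of the two numbers, but the separation a 1.8-fold lower number from compound 1 to compound 2 (0.26 log units; within the scatter) is within the scatter, so the two compounds are not told apart. Compound 3 `Nc1n[nH]c2cccc(-c3cccc(NC(=O)Nc4cccc(Cl)c4)c3)c12` differs from compound 2 by chloro in place of isopropyl on an aromatic carbon, read one bond further out as 3-isopropylphenyl to 3-chlorophenyl. Among the compounds with values here, the only measured step, from compound 1 to compound 2, alters the same ring in a different way and bears on this change only loosely. For compound 3 no step beyond the scatter is expected: estimated a 1.4-fold higher number from compound 2 to compound 3 (0.15 log units; within the scatter), giving 400 nM with a range of 180 nM to 900 nM.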

Compound 3, half-maximal inhibitory concentration: 1830 nM
The estimate for compound 3 lay 4.6-fold (0.66 log units) below the measured number; measured number outside the range, above it.
By their numbers in this assay, from the lowest: compounds 2 and 1 (each within the scatter of the next); then compound 3.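

In this assay the substituent on this ring now matters: chloro in place of isopropyl gives a 6.5-fold higher number from compound 2 to compound 3 (0.82 log units; beyond the scatter) and this step lies beyond the scatter, unlike the step between the earlier pair. Hydrogen in place of methyl on an aromatic carbon gives a 3.6-fold higher number from compound 1 to compound 3 (0.55 log units; beyond the scatter) and this step also lies beyond the scatter, so the chloro group alone does not match compound 1. Nothing available accounts for either step.

From the compounds shown here alone, how other groups read in place of isopropyl remains open, for instance methoxy or an amine. Going by these compounds, whether methyl alone, without chloro, holds the lower numbers also remains open.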